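Acetyl to thiazolylcarbonyl on the shared core

This account rests on a few compounds, and the source may have more. Where it says the series, first, only, none or still open, it means among the compounds named here.

Compound 1, `CCCCNc1nc(N)nc2c1CN(C(C)=O)CC2`: 0.5 uM
Compound 2, `CCCCNc1nc(N)nc2c1CCN(C(=O)c1ccccc1)C2`: 0.8 uM

In an assay on HEK293 cells for agonist activity at Toll-like receptor 8 (Homo sapiens), read by a luciferase reporter, with a stated time of 6 h (a lower number here means that less compound is needed, a higher number that more compound is needed for the effect), compound 1 gives 0.5 uM, the lower of the two numbers, while compound 2 gives 0.8 uM, within the scatter of compound 1. Compound 3, `CCCCNc1nc(N)nc2c1CN(C(=O)c1scnc1C)CC2`, is not yet measured; it differs from compound 1 by 4-methyl-1,3-thiazol-5-yl in place of methyl on a carbonyl carbon. Because compound 2 gives 0.8 uM with a larger acyl group than compound 1, the step of no change at the digits printed from compound 1 to compound 3 (within the scatter) is expected to be small, if any, in either direction. Compound 3 is therefore estimated at 0.5 uM, with a range from 0.15 uM to 2 uM.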

Compound 3, minimum effective concentration: 5.6 uM
Estimate against measurement, compound 3: 11-fold (1.05 log units) below, outside the stated range (above it).
By their numbers in this assay, from the lowest: compounds 1 and 2 (each within the scatter of the next); then compound 3.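

In this assay the change of methyl to 4-methyl-1,3-thiazol-5-yl on a carbonyl carbon brings an 11-fold higher number from compound 1 to compound 3 (1.05 log units; beyond the scatter) and shows that this position of the shared core does not accept every acyl group alike. For the compounds shown here, this single-place pair is the first to show such a step at this position. Nothing measured here explains the step.

On these data alone, whether the higher number comes from the thiazole ring or from its methyl remains open. An unsubstituted thiazol-5-yl or a cyclopropyl on the same carbonyl carbon would help separate these possibilities.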